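A few compounds are considered here, and "the series" means these few. Any claim that something is new, unique, unknown or untested is made for them only; others in the source may bear on it.

In a functional assay on the whole organism with Canis familiaris (Canis lupus familiaris) as the target (a lower number here means that less compound is needed, a higher number that more compound is needed for the effect), compound 1 (`CC(=O)OC(CSc1[nH]cnc2ncnc1-2)CN1CCN(C(c2ccc(F)cc2)c2ccc(F)cc2)CC1`) gives 0.3 mg/kg. Compound 2 (`O=S(=O)(O)OC(CSc1[nH]cnc2ncnc1-2)CN1CCN(C(c2ccc(F)cc2)c2ccc(F)cc2)CC1`) gives 0.26 mg/kg, a result that sits within the scatter of compound 1, as a 1.2-fold lower number from compound 1 to compound 2 (0.06 log units; within the scatter) shows. Compound 3 (`Fc1ccc(C(c2ccc(F)cc2)N2CCN(CCCSc3[nH]cnc4ncnc3-4)CC2)cc1`) gives 1.3 mg/kg, which makes a 4.3-fold higher number from compound 1 to compound 3 (0.64 log units; beyond the scatter) and a 5.0-fold higher number from compound 2 to compound 3 (0.70 log units; beyond the scatter). Compound 4 (`CC(=O)OC(CNc1[nH]cnc2ncnc1-2)CN1CCN(C(c2ccc(F)cc2)c2ccc(F)cc2)CC1`) carries a group of 10 heavy atoms (5 carbon, 5 nitrogen; one five-membered aromatic ring with 2 hetero atoms, one six-membered aromatic ring with 2 hetero atoms) in place of a group of 10 heavy atoms (5 carbon, 4 nitrogen, 1 sulfur; one five-membered aromatic ring with 2 hetero atoms, one six-membered aromatic ring with 2 hetero atoms), on a saturated chain carbon, two bonds along the chain from an oxygen next to a carbonyl group. Among the compounds with values here, no measured step touches this group. The steps to compound 3 only show the size a single change elsewhere reached, and they give no direction here. No change beyond the scatter is therefore expected in this assay, and the expected step is a 1.3-fold higher number from compound 1 to compound 4 (0.12 log units; within the scatter). For compound 4 the estimated value is 0.4 mg/kg, with an expected range from 0.12 mg/kg to 1.3 mg/kg.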

Compound 4, dose for half-maximal effect: 0.27 mg/kg
Estimate against measurement, compound 4: 1.5-fold (0.17 log units) above; low and high end bracket the measured number.
By their numbers in this assay, from the lowest: compounds 2, 4 and 1 (each within the scatter of the next); then compound 3.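

In this assay, within the data shown here, the group on a saturated chain carbon, two bonds along the chain from an oxygen next to a carbonyl group, changes here for the first time, and the swap of the group with 1 sulfur for the group with 5 nitrogen gives a 1.1-fold lower number from compound 1 to compound 4 (0.05 log units; within the scatter) and so stays within the scatter. This group can therefore differ in this way, with one more hydrogen-bond donor by count, without a measurable shift in this pair. Nothing available accounts for this result. On these data alone, whether the same swap would hold with the sulfooxy group of compound 2 or the plain chain of compound 3 remains open. So does the outcome of an ether oxygen or a methylated amine in place of the sulfur.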